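This account rests on a few compounds, and the source may have more. Where it says the series, first, only, none or still open, it means among the compounds named here.

Among the measured compounds shown here, compound 2 `N#Cc1ccc(-c2ccc(CO[C@@H]3COc4nc([N+](=O)[O-])cn4C3)cc2)cc1` stands at the top of the two numbers measured so far: in an ADME assay on microsomes from liver (Mus musculus, strain CD1) for metabolic stability, read by LC-MS, with a stated time of 1 h (on this read-out higher numbers stand for a more stable compound and lower numbers for a less stable compound), compound 2 gives 58%, whereas compound 1 `CCOc1ccccc1-c1ccc(CO[C@@H]2COc3nc([N+](=O)[O-])cn3C2)cc1` gives 0.2%. For the measured compounds named here, the one step on hand, a number 57.8 percentage points higher from compound 1 to compound 2 (beyond the scatter), shows how strongly the group on this aromatic carbon can shift the outcome. Compound 3 `O=[N+]([O-])c1cn2c(n1)OC[C@@H](OCc1ccc(-c3ccc(Oc4ccccc4)cc3)cc1)C2` carries phenoxy in place of cyano on an aromatic carbon. That single measured step runs the other way and concerns a different pair of groups, so it offers only a loose guide; still, a large downward step is expected: a number 48 percentage points lower from compound 2 to compound 3 (beyond the scatter). For compound 3 the expected value is 10%, with a range from 1% to 40%.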

Compound 3, percent of the compound remaining: 48%
Beside the measured number, compound 3's estimate is 38 percentage points below it; measured number outside the range, above it.
By their numbers in this assay, from the lowest: compound 1; then compounds 3 and 2 (each within the scatter of the next).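

In this assay, the change from cyano to phenoxy, para to a large group, gives a number 10 percentage points lower from compound 2 to compound 3 (within the scatter). So this aromatic carbon can carry a much bigger group, one with its own six-membered aromatic ring, without moving the number beyond the usual scatter. Nothing on hand explains this result. As far as these compounds go, whether a small amine or a carboxylic acid on this carbon would also stay within the scatter of compound 2 remains open. So does the outcome with a longer chain, such as butoxy, in place of phenoxy.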